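Swapping the trimethoxyphenyl for methoxyphenyl on compound 3

The source may report more compounds than this note shows. Statements on the series, on what has been measured and on what is new or still open speak of the compounds shown alone.

Measured compounds:
- compound 1, `COc1ccc(C(=O)c2ccc3c(ccn3Cc3ccc(C(=O)NO)cc3)c2)cc1`: 646 nM
- compound 2, `COc1cc(C(=O)c2ccc3c(ccn3Cc3ccc(C(=O)NO)cc3)c2)cc(OC)c1OC`: "not determined" (no result reported)
- compound 3, `COc1cc(C(=O)c2ccc3c(ccn3Cc3ccc(/C=C/C(=O)NO)cc3)c2)cc(OC)c1OC`: 2170 nM

All three compounds share a core carrying a ketone on one side and a hydroxamic acid group on the other. In an assay on isolated protein for inhibition of histone deacetylase 8 (Homo sapiens) (on this read-out higher numbers stand for weaker inhibition and lower numbers for stronger inhibition), compound 1 gives 646 nM, while compound 3 gives 2170 nM. Compound 3 thus stands at the higher of the two reported numbers, and its gap to compound 1 lies beyond the usual scatter of repeated measurements. Going by the values given here, for compound 2 the entry in this assay reads "not determined" (no result reported), so the pair of compound 2 and compound 3, which differ only in the linker to the hydroxamic acid, gives no step to lean on.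

Compound 4, `COc1ccc(C(=O)c2ccc3c(ccn3Cc3ccc(/C=C/C(=O)NO)cc3)c2)cc1`, is reached from compound 3 by the change (4-methoxyphenyl in place of 3,4,5-trimethoxyphenyl on a carbonyl carbon). Compound 1 and compound 3 differ in two places at once, so their numbers alone cannot isolate what this single change on the carbonyl does. Among the compounds with values here, with no closely matched pair to guide it, the expectation for compound 4 is a small step, if any, toward a lower number in this assay, not clearly beyond the scatter: a 1.4-fold lower number from compound 3 to compound 4 (0.16 log units; within the scatter). The estimate for compound 4 is therefore 1500 nM, with a range from 500 nM to 4500 nM.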

Compound 4, half-maximal inhibitory concentration: 2810 nM
For compound 4 the middle estimate is 1.9-fold (0.27 log units) below the measured one; low and high end bracket the measured number.
By their numbers in this assay, from the lowest: compound 1; then compounds 3 and 4 (each within the scatter of the next).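

In this assay, 4-methoxyphenyl in place of 3,4,5-trimethoxyphenyl on a carbonyl carbon gives a 1.3-fold higher number from compound 3 to compound 4 (0.11 log units; within the scatter) and so leaves the read-out within the usual scatter, even though this change removes two of the methoxy groups. Going by these compounds alone, compound 4 also gives the first comparison in which only the link to the hydroxamic acid differs: 2-(hydroxycarbamoyl)ethenyl in place of hydroxycarbamoyl on an aromatic carbon gives a 4.3-fold higher number from compound 1 to compound 4 (0.64 log units; beyond the scatter) as a modest step that clears the scatter, so in this small set a change at this second place moves the number while the change on the carbonyl carbon does not. The data shown offer no independent measurement that would explain either result.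

Compound 2 has no number, so its steps cannot be read, and the effect of the link is known only with 4-methoxyphenyl on the carbonyl carbon. Going by these compounds, it also remains open how a phenyl group carrying an amine or a carboxylic acid would read on that carbonyl carbon, and how a longer chain in place of 2-(hydroxycarbamoyl)ethenyl would read.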